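Extending the amine chain of compound 1 by one carbon

The compounds below may be only part of what the source reports. "The series", "measured", "known", "first", "only" and "open" are said of these compounds alone.

Measured compounds:
- compound 1, `CCNC(c1ccnc(Nc2ccc(C#N)cc2)n1)c1ccccc1Cl`: 39400 nM
- compound 2, `CNC(c1ccc(/C=C/C#N)cc1)c1ccnc(Nc2ccc(C#N)cc2)n1`: 41400 nM
- compound 3, `N#C/C=C/c1ccc(C(NC2CC2)c2ccnc(Nc3ccc(C#N)cc3)n2)cc1`: 56100 nM

All three compounds share a core and were tested in an ADME assay on MT4 cells (Homo sapiens) for cytotoxicity, read by MTT assay, with a stated time of 5 days; on this read-out higher numbers stand for lower toxicity in this test and lower numbers for higher toxicity in this test. In this assay compound 1 gives 39400 nM. Compound 2 gives 41400 nM and compound 3 gives 56100 nM; both of these lie within the usual scatter of the number for compound 1, so the three compounds cannot be told apart on this read-out.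

Compound 4, `CCCNC(c1ccnc(Nc2ccc(C#N)cc2)n1)c1ccccc1Cl`, has not yet been measured. It differs from compound 1 in one place: methyl in place of hydrogen on a saturated chain carbon, two bonds along the chain from an amine nitrogen. Among the compounds with values here, the only measured step that touches the substituent on the amine nitrogen is the one from compound 2 to compound 3, where a larger group replaced a smaller one on that nitrogen, and this gave a 1.4-fold higher number from compound 2 to compound 3 (0.13 log units; within the scatter). That step is the closest guide available, and it moved nothing beyond the scatter.

On this basis no step beyond the scatter is expected for compound 4, so the estimate is a 1.1-fold lower number from compound 1 to compound 4 (0.04 log units; within the scatter). Compound 4 is therefore expected to give about 36000 nM in this assay, with a likely range from 15000 nM to 85000 nM.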

Compound 4, half-maximal cytotoxic concentration: 68500 nM
Beside the measured number, compound 4's estimate is 1.9-fold (0.28 log units) below it, within the range that was stated.
By their numbers in this assay, from the lowest: compounds 1, 2, 3 and 4 (each within the scatter of the next).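

Replacing hydrogen with methyl on a saturated chain carbon, two bonds along the chain from an amine nitrogen, turns ethylamino into propylamino and gives, in this assay, a 1.7-fold higher number from compound 1 to compound 4 (0.24 log units; within the scatter), so this one-carbon extension cannot be told from repeat-measurement noise. The earlier compounds shown here showed only a swap of methyl for cyclopropyl on the amine nitrogen, in a different compound; this result adds that a straight chain on that nitrogen can grow from ethyl to propyl with no step beyond the scatter on this read-out. No supporting measurement accompanies the result to explain the number for compound 4.

The compounds shown leave open whether a longer chain such as butyl, a branched chain such as isopropyl, or a chain ending in a hydroxyl group or an amine on this nitrogen would also stay within the scatter of compound 1. They also leave open whether the same ethyl-to-propyl change would read the same way on a compound carrying the other substituents of compound 2 or compound 3.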